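Swapping sec-butyl for 3-(dibutylamino)propyl

The source may hold more compounds than are shown below. What is called first, only, known or untested is meant among the compounds shown, and "the series" means these compounds.

Measured in a functional assay on LNCaP cells (Homo sapiens) for antiproliferative activity, read by WST assay, with a stated time of 3 days; on this read-out higher numbers stand for weaker inhibition and lower numbers for stronger inhibition:
- compound 1 `CCCOc1c(-c2cc(OC)c(OC)c(OC)c2)oc2ccccc2c1=O`: 5700 nM
- compound 2 `CCC(C)Oc1c(-c2cc(OC)c(OC)c(OC)c2)oc2ccccc2c1=O`: 9300 nM

Among the measured compounds shown here, only two numbers exist so far, and compound 2, at 9300 nM, sits within the usual scatter of compound 1. The next structure, compound 3 `CCCCN(CCCC)CCCOc1c(-c2cc(OC)c(OC)c(OC)c2)oc2ccccc2c1=O`, carries 3-(dibutylamino)propyl in place of sec-butyl on an oxygen on an aromatic ring. For the measured compounds named here, the only measured step is a 1.6-fold higher number from compound 1 to compound 2 (0.21 log units; within the scatter), and it comes from adding a single methyl. That small step says little about a change of this size. Going by the values given here, no measured compound carries a nitrogen-bearing chain. The direction therefore remains uncertain, and only a tentative lean towards stronger inhibition is made here. The expected step is a 3.7-fold lower number from compound 2 to compound 3 (0.57 log units; beyond the scatter). In this assay, compound 3 is estimated at 2500 nM, with a range of 500 nM to 10000 nM.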

Compound 3, half-maximal inhibitory concentration: 9000 nM
The estimate for compound 3 lay 3.6-fold (0.56 log units) below the measured number; measured number inside the range.
By their numbers in this assay, from the lowest: compounds 1, 3 and 2 (each within the scatter of the next).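

In this assay, 3-(dibutylamino)propyl in place of sec-butyl on an oxygen on an aromatic ring gives a 1.0-fold lower number from compound 2 to compound 3 (0.01 log units; within the scatter), so this oxygen can carry a far larger chain, one holding a nitrogen, with no reading beyond the scatter. Measured against the unbranched chain, dibutylamino in place of hydrogen on a saturated chain carbon, three bonds along the chain from an oxygen on an aromatic ring, gives a 1.6-fold higher number from compound 1 to compound 3 (0.20 log units; within the scatter), which is also within the scatter. Nothing available explains why such different chains give numbers that cannot be told apart.

Going by these compounds, it remains open whether a smaller amine such as dimethylamino, or a ring amine such as piperidine, on the same propyl chain would move the number beyond the scatter. The same question stands for a carboxylic acid at that place.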